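From propoxy to 4-bromophenoxy: one growth inhibition step

A few compounds are considered here, and "the series" means these few. Any claim that something is new, unique, unknown or untested is made for them only; others in the source may bear on it.

Measured in a functional assay on HCT-116 cells (Homo sapiens) for inhibition, read by sulforhodamine B assay, with a stated time of 48 h, tested at 50 uM; a higher number here means more inhibition of growth at the concentration tested, a lower number less inhibition of growth:
- compound 1 `CCCOc1ccc([C@@H]2CC(=O)c3cc(CC=C(C)C)c(OC)cc3O2)cc1`: 63%
- compound 2 `COc1ccc([C@@H]2C/C(=N/OCc3cn(-c4ccc(O)cc4)nn3)c3cc(CC=C(C)C)c(OC)cc3O2)cc1`: 65%
- compound 3 `COc1cc2c(cc1CC=C(C)C)[C@H](O)C[C@@H](c1ccc(O)cc1)O2`: 37%

Compound 1, at 63%, cannot be separated from compound 2, at 65%. Compound 3, at 37%, lies beyond the scatter under compound 1, which leaves compound 1 in the upper pair of this small set.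

The unmeasured compound 4 `COc1cc2c(cc1CC=C(C)C)C(=O)C[C@@H](c1ccc(Oc3ccc(Br)cc3)cc1)O2` keeps the core of compound 1 and changes one group: 4-bromophenyl in place of propyl on an oxygen on an aromatic ring. In words, 4-bromophenyl stands in place of propyl on an oxygen on an aromatic ring.

Within the data shown here, no two measured compounds differ in one place, so the data hold no direct precedent for this change. In this assay, the expectation is therefore no step beyond the scatter, in either direction. The estimated change is a number 1 percentage points lower from compound 1 to compound 4 (within the scatter), which is expected to stay small. The expected value for compound 4 is 62%, with an estimated range from 42% to 82%.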

Compound 4, percent growth inhibition at one concentration: 76%
Estimate against measurement, compound 4: 14 percentage points below; low and high end bracket the measured number.
By their numbers in this assay, from the lowest: compound 3; then compounds 1 and 2 (each within the scatter of the next); then compound 4.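

In this assay, the oxygen on an aromatic ring proves to be a place where the choice of group can shift growth inhibition: with 4-bromophenyl in place of propyl, the change reads a number 13 percentage points higher from compound 1 to compound 4 (beyond the scatter). Among these compounds, this is the only step in the set that isolates a single change, and it shows that the shared core keeps its growth inhibition at the concentration tested when this group carries a six-membered aromatic ring and a bromine. Nothing available gives a reason for the step.

As far as these compounds go, what stays open is whether the bromine or the ring carries the step, a question that a plain phenyl or a 4-chlorophenyl on the same oxygen would settle. A longer chain such as hexyl there would show whether a ring is needed at all.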